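The source may report more compounds than this note shows. Statements on the series, on what has been measured and on what is new or still open speak of the compounds shown alone.

Measured in a functional assay on HepG2 cells (Homo sapiens) for inhibition, read by MTT assay, with a stated time of 72 h; a higher number here means a weaker inhibitor, a lower number a stronger inhibitor:
- compound 1 `COc1ccc(/C=C/C(=O)c2c(OC)cc(O)c(CC=C(C)C)c2O)cc1`: 32400 nM
- compound 2 `COc1cc(O)c(CC=C(C)C)c(O)c1C(=O)/C=C/c1ccc(O)c(O)c1`: 15200 nM
- compound 3 `COc1cc(/C=C/C(=O)c2c(OC)cc(O)c(CC=C(C)C)c2O)cc(OC)c1OC`: > 50000 nM, a limit of the assay and not a number

Of the two actual numbers, the lower belongs to compound 2, so it is the stronger inhibitor of that pair. Compound 3 sits at the limit of > 50000 nM in this assay, at which 1 of the 3 values shown sits.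

Compound 4 `COc1cc(O)c(CC=C(C)C)c(O)c1C(=O)/C=C/c1ccc([N+](=O)[O-])cc1` carries 4-nitrophenyl in place of 3,4-dihydroxyphenyl on a double-bonded chain carbon bound to a double-bonded chain carbon.

Going by the values given here, the one measured step that bears on this change is a 2.1-fold lower number from compound 1 to compound 2 (0.33 log units; beyond the scatter). It is modest but beyond the scatter, and it brought 3,4-dihydroxyphenyl in for 4-methoxyphenyl. Among the compounds with values here, compound 4 gives up that same group, although no measured step shows what 4-nitrophenyl itself does. A modest move toward a higher number in this assay is therefore expected, about as large as that earlier step, and a limit remains possible. The expected change is a 1.8-fold higher number from compound 2 to compound 4 (0.27 log units; within the scatter). Compound 4 is estimated at 28000 nM, with an expected range of 12000 nM to 50000 nM.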

Compound 4, half-maximal inhibitory concentration: 12400 nM
Compound 4: middle estimate off by 2.3-fold (0.35 log units), on the high side, within the range that was stated.
By their numbers in this assay, from the lowest: compounds 4 and 2 (each within the scatter of the next); then compound 1. At a limit, above all of these: compound 3.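

In this assay, replacing 3,4-dihydroxyphenyl with 4-nitrophenyl at this place gives a 1.2-fold lower number from compound 2 to compound 4 (0.09 log units; within the scatter), so a group with 0 hydrogen-bond donors reads the same here as one with 2, and those donors are not required for this level of inhibition. The earlier compounds shown here could not show this, since they left open whether the catechol-like pair of hydroxyls itself set the lower number; the nitro compound also differs clearly from the methoxy compound, with a 2.6-fold lower number from compound 1 to compound 4 (0.42 log units; beyond the scatter) as the step. Nothing measured here explains why these two different groups read alike.

The compounds shown leave open how an amine or a carboxylic acid would read at this place on the aromatic ring. Also open, as far as these compounds go, is how a plain unsubstituted phenyl would compare.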